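The compounds below may be only part of what the source reports. "The series", "measured", "known", "first", "only" and "open" are said of these compounds alone.

Measured so far in a functional assay on HeLa cells (Homo sapiens) for antiproliferative activity, read by MTT assay, with a stated time of 48 h; on this read-out lower numbers stand for stronger inhibition and higher numbers for weaker inhibition:
- compound 1 `CN(C)CCn1c(N)c(-c2nc3ccccc3[nH]2)c2nc(C#N)c(C#N)nc21`: 8880 nM
- compound 2 `CCCn1c(N)c(-c2nc3ccccc3[nH]2)c2nc(C#N)c(C#N)nc21`: > 50000 nM, a limit of the assay
- compound 3 `N#Cc1nc2c(-c3nc4ccccc4[nH]3)c(N)n(CCCO)c2nc1C#N`: > 50000 nM, a limit of the assay

Among the compounds with values here, compound 1 is the only member with a number in this assay; the other two sit at the limit of > 50000 nM in this assay, at which 2 of the 3 values shown sit. Both measured steps remove the dimethylamino: an at least 5.6-fold higher number from compound 1 to compound 2 (0.75 log units; beyond the scatter) and an at least 5.6-fold higher number from compound 1 to compound 3 (0.75 log units; beyond the scatter). The step between compound 2 and compound 3 is a step that the two limits leave unreadable from compound 2 to compound 3.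

Compound 4 `N#Cc1nc2c(-c3nc4ccccc4[nH]3)c(N)n(CCCNc3ccccc3)c2nc1C#N` differs from compound 1 as follows: anilinomethyl in place of dimethylamino on a saturated chain carbon, two bonds along the chain from an aromatic nitrogen. Here again the dimethylamino leaves, as in the steps to compound 2 and compound 3, though this time a nitrogen re-enters on a longer group with an aromatic ring. Given an at least 5.6-fold higher number from compound 1 to compound 2 (0.75 log units; beyond the scatter) and an at least 5.6-fold higher number from compound 1 to compound 3 (0.75 log units; beyond the scatter), compound 4 is expected to give a higher number than compound 1 in this assay, with a real chance of only a limit. The estimated step is a 3.4-fold higher number from compound 1 to compound 4 (0.53 log units; beyond the scatter); compound 4 is estimated at 30000 nM, between 8000 nM and 60000 nM.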

Compound 4, half-maximal inhibitory concentration: 26300 nM
For compound 4 the middle estimate is 1.1-fold (0.06 log units) above the measured one; the range from low to high includes it.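

In this assay, removing dimethylamino at this place on the chain does not always end at a limit: anilinomethyl returns a number, with a 3.0-fold higher number from compound 1 to compound 4 (0.47 log units; beyond the scatter), so compound 1 still gives the lowest number of the four. Against the other two members, the readings are only floors, an at least 1.9-fold lower number from compound 3 to compound 4 (0.27 log units; that floor lies within the scatter) and an at least 1.9-fold lower number from compound 2 to compound 4 (0.27 log units; that floor lies within the scatter), so compound 4 cannot be ordered against either. Compound 2 and compound 3 remain at a limit of the assay: the limit of > 50000 nM in this assay, at which 2 of the 4 values shown sit.

Going from 2-(dimethylamino)ethyl to 3-anilinopropyl alters the chain and the group on its nitrogen in one step, so the two contributions cannot be separated. On these data alone, how a longer chain carrying dimethylamino, or a piperidine or morpholine in place of dimethylamino, would read remains open.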